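Hydroxamate series: aryl substituent change at the anilino ring

A few compounds are considered here, and "the series" means these few. Any claim that something is new, unique, unknown or untested is made for them only; others in the source may bear on it.

Going by the values given here, compound 3 `O=C(CCCCCCn1cc(Nc2ncc(Cl)c(Nc3ccc(Cl)cc3)n2)cn1)NO` gives 120 nM in a functional assay on MOLT-4 cells (Homo sapiens) for antiproliferative activity, read by MTT assay, with a stated time of 48 h (a lower number here means a stronger inhibitor, a higher number a weaker inhibitor), the lowest of the three numbers so far. Compound 2 `O=C(CCCCCCn1cc(Nc2ncc(Cl)c(Nc3cccc(Cl)c3)n2)cn1)NO` gives 130 nM; the step of a 1.1-fold lower number from compound 2 to compound 3 (0.03 log units; within the scatter) is within the scatter. Compound 1 `O=C(CCCCCn1cc(Nc2ncc(Cl)c(Nc3ccccc3Cl)n2)cn1)NO`, which differs in both the chain length and the position of the chloro group, gives 630 nM, and the two values of compound 1 and compound 3 lie beyond the scatter of each other.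

Compound 4 `COc1ccc(Nc2nc(Nc3cnn(CCCCCCC(=O)NO)c3)ncc2Cl)cc1` is yet to be measured. Relative to compound 3 the change is methoxy in place of chloro on an aromatic carbon. Among the compounds with values here, no measured step covers a methoxy group at this ring; the one step that touches the same ring, a 1.1-fold lower number from compound 2 to compound 3 (0.03 log units; within the scatter), moved the chloro group rather than replacing it and stayed within the scatter. Within the data shown here, that step is the only guide, and it argues for a substituent change on this ring being tolerated, without saying whether a methoxy group is.

On that basis compound 4 is expected to stay close to compound 3, with a step of a 1.3-fold higher number from compound 3 to compound 4 (0.10 log units; within the scatter) that is not expected to exceed the scatter. The estimate for compound 4 is 150 nM, with a range from 60 nM to 400 nM.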

Compound 4, half-maximal inhibitory concentration: 170 nM
Beside the measured number, compound 4's estimate is 1.1-fold (0.05 log units) below it; low and high end bracket the measured number.
By their numbers in this assay, from the lowest: compounds 3, 2 and 4 (each within the scatter of the next); then compound 1.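

In this assay, the change of chloro to methoxy on the aromatic carbon para to a large group gives a 1.4-fold higher number from compound 3 to compound 4 (0.15 log units; within the scatter), so at this position a group other than chloro, one that brings a hydrogen-bond acceptor, still leaves the number within the scatter. The earlier compounds shown here only moved the chloro group around this ring, and the wider comparison gives a 1.3-fold higher number from compound 2 to compound 4 (0.12 log units; within the scatter), so the 4-methoxyphenyl and 3-chlorophenyl groups cannot be told apart in this read-out either. No measurement is at hand that could account for this tolerance.

The compounds shown carry only chloro and methoxy on this ring, which leaves open whether an amine, a carboxylic acid or a larger group such as a phenyl ring at the same position would also stay within the scatter of compound 3. Compound 1 differs from the others in more than one place, so the effect of chain length remains unresolved, and a longer or shorter chain paired with the 4-chlorophenyl or 4-methoxyphenyl group would be needed to isolate it.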